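Exchanging a five-membered aromatic ring on compound 2

This account rests on a few compounds, and the source may have more. Where it says the series, first, only, none or still open, it means among the compounds named here.

In a functional assay on CWR22R cells (Homo sapiens) for antiproliferative activity, read by CCK-8 assay, with a stated time of 6 days (a lower number here means a stronger inhibitor, a higher number a weaker inhibitor), compound 1 `N#Cc1ccc(N2CCCc3c(-c4cccnc4)cccc32)cc1C(F)(F)F` gives 12300 nM, while compound 2 `CCN(c1ccc(C#N)c(Cl)c1)c1cc(-c2ccnn2C)ccc1C` gives 4330 nM. Compound 2 therefore holds the lower of the two numbers, and the gap between them lies beyond the scatter. These two compounds differ in more than one place, so no measured single change is available as a guide. Compound 3 `CCN(c1ccc(C#N)c(Cl)c1)c1cc(-n2ccnc2)ccc1C` keeps the rest of compound 2 but has 1H-imidazol-1-yl in place of 1-methyl-1H-pyrazol-5-yl on an aromatic carbon. Among the compounds with values here, both groups are five-membered aromatic rings, and no measured pair shows what this exchange does. In this assay, the expected change is small and has no firm direction: an estimated step of a 1.2-fold higher number from compound 2 to compound 3 (0.06 log units; within the scatter) would stay within the scatter. For compound 3 the estimated value is 5000 nM, with an expected range from 1800 nM to 14000 nM.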

Compound 3, half-maximal inhibitory concentration: > 30000 nM
Compound 3 ended at the assay's limit (the forecaster's own chance of this, stated with the estimate: 10%); middle value at least 6.0-fold (0.77 log units) away from the limit.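

In this assay, the exchange of 1-methyl-1H-pyrazol-5-yl for 1H-imidazol-1-yl is not neutral, as the measured pair gives an at least 6.9-fold higher number from compound 2 to compound 3 (0.84 log units; beyond the scatter). This position, on an aromatic carbon para to a methyl group, therefore does not treat these two five-membered aromatic rings alike, even though each has 2 hetero atoms, 0 hydrogen-bond donors and 2 hydrogen-bond acceptors. The value of compound 3 is a limit of the assay, so the step gives only a lower bound on the loss: the limit of > 30000 nM in this assay, at which 1 of the 3 values shown sits.

The compounds shown do not separate the part played by the methyl group of the departing ring from that of the way each ring is attached. From the compounds shown here alone, how a 1-methyl-1H-imidazol-5-yl group or a simple amine would behave at this position also remains open.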